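Compound 1 to compound 4: cyano to trifluoromethyl

A few compounds are considered here, and "the series" means these few. Any claim that something is new, unique, unknown or untested is made for them only; others in the source may bear on it.

Measured in an ADME assay on microsomes from liver (Rattus norvegicus) for metabolic stability, read by LC-MS, using NADPH, tested at 3 uM; a lower number here means that the compound disappears faster, a higher number that the compound lasts longer:
- compound 1 `N#CCC(c1ccccc1)c1c(-c2ccccc2)[nH]c2cc(Cl)ccc12` gives 0.375 h
- compound 2 `O=C(C(c1ccccc1)c1c(-c2ccccc2)[nH]c2ccccc12)C(F)(F)F` gives 0.69 h
- compound 3 `Cc1ccc2c(C(CC(F)(F)F)c3ccco3)c(-c3ccccc3)[nH]c2c1` gives 0.172 h

Compound 1 lies within the scatter of compound 2 and higher than compound 3, with that gap beyond the scatter. Compound 4 `FC(F)(F)CC(c1ccccc1)c1c(-c2ccccc2)[nH]c2cc(Cl)ccc12` has trifluoromethyl in place of cyano on a saturated chain carbon, two bonds along the chain from two aromatic carbons. Among the measured compounds shown here, no measured pair isolates this change. Compound 3 also carries 2,2,2-trifluoroethyl but differs elsewhere, and it gives 0.172 h. The expected 1.3-fold lower number from compound 1 to compound 4 (0.13 log units; within the scatter) is a small decrease, not beyond the scatter. For compound 4 the estimate is 0.28 h, with an expected range of 0.13 h to 0.6 h.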

Compound 4, half-life: 1.3 h
The estimate for compound 4 lay 4.6-fold (0.67 log units) below the measured number, and the stated range ends below it.
By their numbers in this assay, from the lowest: compound 3; then compounds 1, 2 and 4 (each within the scatter of the next, the first and the last beyond it).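

In this assay, among the compounds shown here, trifluoromethyl in place of cyano on a saturated chain carbon gives a 3.5-fold higher number from compound 1 to compound 4 (0.54 log units; beyond the scatter) and is the first single-place change readable. It shows that half-life responds to the group at this position, at least on the core of compound 1. No measurement at hand accounts for the step.

Still open, as far as these compounds go, is whether an amine or a carboxylic acid at this position would shift half-life in the same direction. Also open, from the compounds shown here alone, is whether the same change holds on a different core.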